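Compound 3: swapping in a smaller ring

This account rests on a few compounds, and the source may have more. Where it says the series, first, only, none or still open, it means among the compounds named here.

In an in vitro ADME assay on microsomes from liver (Homo sapiens) for metabolic stability, read by HPLC (on this read-out lower numbers stand for slow clearance and higher numbers for fast clearance), the results so far are:
Compound 1 (`NC(=O)[C@@H](CCC(F)(F)F)N(C[C@@H]1CCCCO1)S(=O)(=O)c1ccc(Cl)cc1`) gives > 300 mL/min/kg (a limit of the assay)
Compound 2 (`NC(=O)[C@@H](CCC(F)(F)F)N(C[C@H]1CCOC1)S(=O)(=O)c1ccc(Cl)cc1`) gives 83.4 mL/min/kg (a measured number)

Going by the values given here, compound 2 holds the only true number here. Compound 1 gives only a limit. Compound 3 (`NC(=O)[C@@H](CCC(F)(F)F)N(C[C@H]1CCO1)S(=O)(=O)c1ccc(Cl)cc1`) differs from compound 2 in one place (oxetan-2-yl in place of oxolan-3-yl on a saturated chain carbon bound to a sulfonamide nitrogen): oxetan-2-yl in place of oxolan-3-yl on a saturated chain carbon bound to a sulfonamide nitrogen. Among the compounds with values here, one measured step bears on this, a similar ring swap at that same place (an at least 3.5-fold lower number from compound 1 to compound 2 (0.55 log units; beyond the scatter)), and it lies beyond the scatter. On that single step, a further but more modest fall is expected (a 2.1-fold lower number from compound 2 to compound 3 (0.32 log units; beyond the scatter)). In this assay the estimated value for compound 3 is 40 mL/min/kg (range 15 mL/min/kg to 100 mL/min/kg).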

Compound 3, clearance: 63.8 mL/min/kg
Estimate against measurement, compound 3: 1.6-fold (0.20 log units) below, within the range that was stated.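

In this assay, the swap of oxolan-3-yl for oxetan-2-yl on a saturated chain carbon bound to a sulfonamide nitrogen gives a 1.3-fold lower number from compound 2 to compound 3 (0.12 log units; within the scatter), so these two rings cannot be told apart here. The clear gap lies instead with oxan-2-yl, shown by an at least 4.7-fold lower number from compound 1 to compound 3 (0.67 log units; beyond the scatter), and its true size is unknown. Compound 1 gives a limit and not a number: the limit of > 300 mL/min/kg in this assay, at which 1 of the 3 values shown sits. Still open, on these data alone, is how a cyclobutyl ring or an amine would fare at this place, and whether the other stereoisomer of oxetan-2-yl would read the same.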